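The source may hold more compounds than are shown below. What is called first, only, known or untested is meant among the compounds shown, and "the series" means these compounds.

Working notes on the series. Among the compounds with values here, compound 2 `Cc1c(-n2c(-c3ccccc3)c(-c3ccccc3)c3c(NN)ncnc32)n(C)n(-c2ccccc2)c1=O` gives 46.2% in a functional assay on the whole organism (strain Sprague-Dawley) for inhibition, with Rattus norvegicus as the target, read by paw edema, with stated times of 1 h and 2 h, at a dose of 70 mg/kg by the subcutaneous route (a lower number here means less inhibition, a higher number more inhibition at the dose given (going by the name of the read-out)), the higher of the two numbers measured so far. Compound 1 `Cc1c(-n2c(-c3ccccc3)c(-c3ccccc3)c3c(Nc4ccccc4)ncnc32)n(C)n(-c2ccccc2)c1=O` gives 5.11% in this assay, and the change from compound 1 to compound 2 is a number 41.1 percentage points higher from compound 1 to compound 2 (beyond the scatter). Compound 3 `Cc1ccccc1Nc1ncnc2c1c(-c1ccccc1)c(-c1ccccc1)n2-c1c(C)c(=O)n(-c2ccccc2)n1C` is not yet measured in this assay; it differs from compound 2 by 2-methylphenyl in place of amino on a nitrogen on an aromatic ring. Within the data shown here, the only step that bears on it is the one from compound 1 to compound 2, which ran in the opposite direction to this change and was large; compound 3 carries an aromatic ring on that nitrogen, as compound 1 does, with a methyl added to it. A large step downward is therefore expected, of the order of a number 36.2 percentage points lower from compound 2 to compound 3 (beyond the scatter), bringing compound 3 back toward the number of compound 1. The expected value for compound 3 in this assay is 10%, with a range from 0% to 30%.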

Compound 3, a percentage reported as inhibition, in the whole organism at one dose (the size of the read-out at that dose, not a potency): 5.17%
Beside the measured number, compound 3's estimate is 4.8 percentage points above it, and the stated range covers the measured number.
By their numbers in this assay, from the lowest: compounds 1 and 3 (each within the scatter of the next); then compound 2.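

In this assay, 2-methylphenyl in place of amino on a nitrogen on an aromatic ring gives a number 41 percentage points lower from compound 2 to compound 3 (beyond the scatter) and is a large step, so the drop seen with phenyl at this place also appears with a second aromatic ring, and amino stands apart from both. Methyl in place of hydrogen on an aromatic carbon gives a number 0.1 percentage points higher from compound 1 to compound 3 (within the scatter) and stays within the scatter, so this added methyl does not separate the two compounds that carry an aromatic ring here. Nothing at hand accounts for the gap between amino and the aromatic groups.

The compounds shown leave open whether a non-aromatic group on this nitrogen, such as a methyl or a butyl chain, stays with compound 2 or falls with compound 1 and compound 3. They also leave open whether methoxy or chloro on the phenyl ring would behave as methyl does.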